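Thiourea Variants on a Shared Core: Toward Compound 4

This account rests on a few compounds, and the source may have more. Where it says the series, first, only, none or still open, it means among the compounds named here.

compound 1, `CNC(=O)c1ccc(Oc2cccc(NC(=S)Nc3ccc(OC(F)(F)F)cc3)c2)nc1`: > 100000 nM
compound 2, `CNC(=O)c1ccc(Oc2cccc(NC(=S)Nc3ccc(C)c(C)c3)c2)nc1`: > 100000 nM
compound 3, `CNC(=O)c1ccc(Oc2cccc(NC(=S)Nc3ccc(F)c(F)c3)c2)nc1`: 26700 nM

In a functional assay on HepG2 cells (Homo sapiens) for antiproliferative activity, read by MTT assay (on this read-out higher numbers stand for weaker inhibition and lower numbers for stronger inhibition), compound 1 gives > 100000 nM, which is a limit of the assay and not a number. Compound 2 also gives only the limit > 100000 nM. Among the compounds with values here, compound 3 gives 26700 nM, the only number among the three. Within the data shown here, the one measured step in a single place is an at least 3.7-fold lower number from compound 2 to compound 3 (0.57 log units; beyond the scatter), set against (the limit of > 100000 nM in this assay, at which 2 of the 3 values shown sit).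

Compound 4, `CNC(=O)c1ccc(Oc2cccc(NC(=S)Nc3cccc(C(F)(F)F)c3)c2)nc1`, differs from compound 3 by 3-(trifluoromethyl)phenyl in place of 3,4-difluorophenyl on an amide-type nitrogen. Among the measured compounds shown here, no measured step matches this change; compound 1 and compound 3 show only that one sits at the limit while the other gives a number. Compound 4 is therefore expected at about 40000 nM, between 10000 nM and 150000 nM, an expected step of a 1.5-fold higher number from compound 3 to compound 4 (0.18 log units; within the scatter), with a real chance of a limit again.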

Compound 4, half-maximal inhibitory concentration: 23300 nM
Estimate against measurement, compound 4: 1.7-fold (0.23 log units) above; low and high end bracket the measured number.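

In this assay, the place on the amide-type nitrogen now holds a second group that gives a number and not a limit, and the swap of 3,4-difluorophenyl for 3-(trifluoromethyl)phenyl leaves a 1.1-fold lower number from compound 3 to compound 4 (0.06 log units; within the scatter), so the two cannot be told apart here. Against 3,4-dimethylphenyl the same group gives an at least 4.2-fold lower number from compound 2 to compound 4 (0.63 log units; beyond the scatter), a step known only as a bound: the limit of > 100000 nM in this assay, at which 2 of the 4 values shown sit. As far as these compounds go, what a nitrile or a carboxylic acid on this phenyl ring would give remains open, as does an amine in its place.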